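Swapping cyclohexyl for phenyl on the ether arm

This account rests on a few compounds, and the source may have more. Where it says the series, first, only, none or still open, it means among the compounds named here.

compound 1, `O=c1c(Cc2coc3cccc(OCC4CCCCC4)c3c2=O)coc2ccccc12`: 4510 nM in a functional assay on PC-3 cells (Homo sapiens) for antiproliferative activity, read by XTT assay; a lower number here means a stronger inhibitor, a higher number a weaker inhibitor
compound 2, `O=c1c(Cc2coc3cccc(OCC4CCCCC4)c3c2=O)coc2cc(Cl)ccc12`: > 10000 nM, a limit of the assay
compound 3, `O=c1c(Cc2coc3cccc(OCC4CCCCC4)c3c2=O)coc2cc(O)ccc12`: 4250 nM

In this assay compound 1 gives 4510 nM. Compound 3 gives 4250 nM, and the step of a 1.1-fold lower number from compound 1 to compound 3 (0.03 log units; within the scatter) sits within the scatter, so the two stand together. For compound 2 the assay reports only a limit, > 10000 nM (the limit of > 10000 nM in this assay, at which 1 of the 3 values shown sits). The step of an at least 2.2-fold higher number from compound 1 to compound 2 (0.34 log units; beyond the scatter) is at least modest, and so is an at least 2.3-fold lower number from compound 2 to compound 3 (0.37 log units; beyond the scatter).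

Compound 4 `O=c1c(Cc2coc3cccc(OCc4ccccc4)c3c2=O)coc2ccccc12` differs from compound 1 on the other arm of the shared core: phenyl in place of cyclohexyl on a saturated chain carbon bound to an oxygen on an aromatic ring. Going by the values given here, none of the measured steps touches that arm; all three concern hydrogen, chloro or hydroxy on an aromatic carbon of the other ring, so no measured step bears directly on this change. With nothing pointing either way, the expected step is none beyond the scatter: a 1.0-fold lower number from compound 1 to compound 4 (0.00 log units; within the scatter). Compound 4 is therefore estimated at about 4500 nM, between 1500 nM and 13000 nM.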

Compound 4, half-maximal inhibitory concentration: 4830 nM
Compound 4: the middle estimate sits 1.1-fold (0.03 log units) below what was measured, within the range that was stated.
By their numbers in this assay, from the lowest: compounds 3, 1 and 4 (each within the scatter of the next). At a limit, above all of these: compound 2.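

In this assay, going by these compounds alone, the step of a 1.1-fold higher number from compound 1 to compound 4 (0.03 log units; within the scatter) gives the first reading on the ether arm, as the earlier steps only concerned hydrogen, chloro or hydroxy on an aromatic carbon of the other ring. For this pair, exchanging cyclohexylmethoxy for benzyloxy leaves the two compounds standing together, so an aromatic and a non-aromatic six-membered ring of carbon cannot be told apart at this place in this assay. Nothing shown here offers a reason for this outcome.

The compounds shown leave open whether an amine on the ring of this arm, or a longer chain between the ring and the ether oxygen, would move the number beyond the scatter. As far as these compounds go, it also remains open whether chloro or hydroxy would give the same steps on the benzyloxy compound 4.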